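A few compounds are considered here, and "the series" means these few. Any claim that something is new, unique, unknown or untested is made for them only; others in the source may bear on it.

The series shares the core of compound 1 `COc1cccc(OC)c1OCCNCCOc1ccccc1OCc1cccc(Cl)c1`. In a functional assay on Vas deferens for antagonist activity at Alpha-1A adrenergic receptor (Rattus norvegicus) (on this read-out higher numbers stand for higher potency (the scale is a negative logarithm) and lower numbers for lower potency), compound 1 gives 8.12. Compound 2 `COc1cccc(OC)c1OCCNCCOc1ccccc1OCc1ccccc1C`, which differs from it only in the group on the saturated chain carbon bound to an oxygen on an aromatic ring, gives 7.81 in this assay, and the step of a number 0.31 log units lower from compound 1 to compound 2 (beyond the scatter) lies beyond the scatter. Among the compounds with values here, compound 2 thus stands lowest of the two numbers so far, with compound 1 the nearest and higher.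

Compound 3 `COc1cccc(OC)c1OCCNCCOc1ccccc1OCc1cccc(C)c1` carries the change (3-methylphenyl in place of 2-methylphenyl on a saturated chain carbon bound to an oxygen on an aromatic ring). Within the data shown here, only one measured step bears on it: the move a number 0.31 log units lower from compound 1 to compound 2 (beyond the scatter) exchanged 3-chlorophenyl for 2-methylphenyl, altering both the substituent and the pattern named in those two groups. Compound 3 keeps the methyl of compound 2 but takes the pattern of the 3-chlorophenyl of compound 1, so a modest gain in this assay is expected, a step of a number 0.19 log units higher from compound 2 to compound 3 (within the scatter). Compound 3 is therefore estimated at 8, with a range from 7.6 to 8.4.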

Compound 3, negative logarithm of the antagonist equilibrium constant: 8.3
Compound 3: the middle estimate sits 0.30 log units below what was measured, and the stated range covers the measured number.
By their numbers in this assay, from the lowest: compound 2; then compounds 1 and 3 (each within the scatter of the next).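

With the same atoms joined differently, 3-methylphenyl in place of 2-methylphenyl on a saturated chain carbon bound to an oxygen on an aromatic ring gives a number 0.49 log units higher from compound 2 to compound 3 (beyond the scatter) in this assay and so moves the number beyond the scatter without any change of group composition. Methyl in place of chloro on an aromatic carbon gives a number 0.18 log units higher from compound 1 to compound 3 (within the scatter) and leaves compound 1 and compound 3 unresolved in this assay. Among these three compounds, the earlier gap between compound 1 and compound 2 therefore goes with the 2-methylphenyl group and not with the exchange of chloro for methyl.

No measurement shown here accounts for the difference between the 2-methylphenyl and 3-methylphenyl groups. Open, going by these compounds, is how a nitrile or an amine in place of the methyl of compound 3 would read in this assay.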